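Adding a Saturated Ring at the Triazole Nitrogen: Toxicity Limits

The source may hold more compounds than are shown below. What is called first, only, known or untested is meant among the compounds shown, and "the series" means these compounds.

Measured compounds:
Compound 1, `CN1C(=S)[C@@H](NC(=O)c2n[nH]c(Cc3ccccc3)n2)COc2ccccc21`: > 50000 nM
Compound 2, `CN1C(=S)[C@@H](NC(=O)c2nc(Cc3ccccc3)n(C3CCOC3)n2)COc2ccccc21`: > 100000 nM
Compound 3, `CN1C(=S)[C@@H](NC(=O)c2nc(Cc3ccccc3)n(C3CCOCC3)n2)COc2ccccc21`: > 100000 nM

In a toxicity assay on HT-29 cells (Homo sapiens) for cytotoxicity (on this read-out higher numbers stand for lower toxicity in this test and lower numbers for higher toxicity in this test), compound 1 gives > 50000 nM, which is a limit of the test rather than a measured number. Compound 2 gives > 100000 nM, also a limit. Compound 3 gives > 100000 nM, again a limit. Compound 1 therefore stands at a limit, and the two further values shown are limits as well, so none of the three compounds is placed as a number in this assay.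

Compound 4, `CN1C(=S)[C@@H](NC(=O)c2nc(Cc3ccccc3)n(CC3COC3)n2)COc2ccccc21`, differs from compound 1 by (oxetan-3-yl)methyl in place of hydrogen on an aromatic nitrogen. For the measured compounds named here, the steps that bear on this change the same position of the shared core: a step that the two limits leave unreadable from compound 1 to compound 2, a step that the two limits leave unreadable from compound 1 to compound 3 and a step that the two limits leave unreadable from compound 2 to compound 3. None of them can be read, because every compound involved sits at the limit of > 100000 nM in this assay, at which 2 of the 3 values shown sit, or at the limit of > 50000 nM in this assay, at which 1 of the 3 values shown sits. Going by the values given here, there is thus no measured step pointing to a change beyond the scatter in either direction, and the expectation is that compound 4 will again be reported at a limit.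

Compound 4 is therefore estimated at 100000 nM, with a range from 50000 nM to 300000 nM. This corresponds to an expected step that the limit leaves unreadable from compound 1 to compound 4.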

Compound 4, half-maximal cytotoxic concentration: > 100000 nM
Compound 4: only a limit was reported; the forecaster's own chance of this, stated with the estimate: 90%; the middle value sits exactly at the limit.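

In this assay, for the compounds shown here, compound 1, compound 2, compound 3 and compound 4 all give limits rather than numbers, so no step involving compound 4 can be read. The compounds shown leave open whether the groups on the aromatic nitrogen differ in toxicity, and at what concentration any of these compounds would become toxic.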